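The source may hold more compounds than are shown below. What is called first, only, known or untested is meant among the compounds shown, and "the series" means these compounds.

Compound 1 `O=S(=O)(Nc1ccc2oc(-c3ccccc3)nc2c1)c1ccccc1O` gives 85000 nM in an assay on cells for inhibition of HSP60/HSP10 (Homo sapiens), with a stated time of 60 min (a lower number here means a stronger inhibitor, a higher number a weaker inhibitor), and holds the highest of the two numbers shown for the series. For the measured compounds named here, compound 3 `O=S(=O)(Nc1ccc(-c2nc3cc(NS(=O)(=O)c4ccccc4O)ccc3o2)cc1)c1ccccc1O` gives 18000 nM in this assay, and the step of a 4.7-fold lower number from compound 1 to compound 3 (0.67 log units; beyond the scatter) is the only measured change between two numbered compounds. Compound 2 `COc1ccc(Cl)cc1S(=O)(=O)Nc1ccc(-c2nc3ccccc3o2)cc1` reaches only a limit of this assay, > 100000 nM. Compound 4 `CCc1ccc(S(=O)(=O)Nc2ccc3oc(-c4ccccc4)nc3c2)cc1` differs from compound 1 by 4-ethylphenyl in place of 2-hydroxyphenyl on a sulfonyl sulfur. Going by the values given here, no measured step alters the aryl on the sulfonyl sulfur, so the step from compound 1 to compound 3 bears only indirectly on this change; the limit of > 100000 nM in this assay, at which 1 of the 3 values shown sits, shows that values beyond the numerical range occur here. Compound 1 already stands at the high end. The expected step of a 1.2-fold higher number from compound 1 to compound 4 (0.07 log units; within the scatter) is none beyond the scatter, or a move toward a weaker number. Compound 4 is estimated at 100000 nM, within 40000 nM to 300000 nM.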

Compound 4, half-maximal inhibitory concentration: > 100000 nM
Compound 4: a limit, no number; the forecaster's own chance of this, stated with the estimate: 55%; the middle value lies on the limit itself.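

For the compounds shown here, this is the first measured change to the aryl on the sulfonyl sulfur: 4-ethylphenyl in place of 2-hydroxyphenyl gives an at least 1.1-fold higher number from compound 1 to compound 4 (0.07 log units; that floor lies within the scatter). Compound 4 gives only a limit in this assay, > 100000 nM, so the step has a floor and no fixed size, and that floor does not establish a real loss. The limit recurs in the series: the limit of > 100000 nM in this assay, at which 2 of the 4 values shown sit.

From the compounds shown here alone, whether the hydroxy or the ethyl group drives the step remains open. So does how an aminophenyl or carboxyphenyl group on the sulfonyl sulfur would read.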